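This account rests on a few compounds, and the source may have more. Where it says the series, first, only, none or still open, it means among the compounds named here.

Compound 3 `CC1=C(SC(C)C(C)O)C(=O)c2ccccc2C1=O` carries a 2-hydroxy-1-methylpropyl on the sulfur of the shared core. In a functional assay on MES-SA cells (Homo sapiens) for inhibition (a lower number here means a stronger inhibitor, a higher number a weaker inhibitor), compound 3 gives only a limit, > 10000 nM. Compound 1 `CC1=C(SCCCO)C(=O)c2ccccc2C1=O` likewise gives only a limit in this assay, > 10000 nM. Compound 2 `CC1=C(SCCCCO)C(=O)c2ccccc2C1=O` also gives only a limit in this assay, > 10000 nM. The steps a step that the two limits leave unreadable from compound 1 to compound 2, a step that the two limits leave unreadable from compound 1 to compound 3 and a step that the two limits leave unreadable from compound 2 to compound 3 cannot be sized because every value sits at the limit of > 10000 nM in this assay, at which 3 of the 3 values shown sit. Compound 4 `CC1=C(SCC(C)O)C(=O)c2ccccc2C1=O` differs from compound 3 by hydrogen in place of methyl on a saturated chain carbon bound to a saturated chain carbon and a sulfur. For the measured compounds named here, no measured step bears on this change with a readable size; all three values so far are limits, and nothing points to a gain. The estimate for compound 4 is therefore a step that the limit leaves unreadable from compound 3 to compound 4, expected to end at 15000 nM with a range from 3000 nM to 60000 nM.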

Compound 4, half-maximal inhibitory concentration: 7110 nM
For compound 4 the middle estimate is 2.1-fold (0.32 log units) above the measured one; the range from low to high includes it.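

In this assay, for the compounds shown here, compound 4, with 2-hydroxypropyl on the sulfur, is the first of the series to give a number instead of a limit. The change gives an at least 1.4-fold lower number from compound 3 to compound 4 (0.14 log units; that floor lies within the scatter), while the other comparisons give an at least 1.4-fold lower number from compound 2 to compound 4 (0.14 log units; that floor lies within the scatter) and an at least 1.4-fold lower number from compound 1 to compound 4 (0.14 log units; that floor lies within the scatter), so each reading is only a floor. The true sizes of these steps, and the steps among compound 1, compound 2 and compound 3, stay unreadable because the other values are limits: the limit of > 10000 nM in this assay, at which 3 of the 4 values shown sit.

From the compounds shown here alone, it remains open whether the hydroxy is needed on this chain. An amine or a carboxylic acid in its place could move the value either way.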